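Moving the chlorine on the triazole-bound phenyl ring

This account rests on a few compounds, and the source may have more. Where it says the series, first, only, none or still open, it means among the compounds named here.

Measured compounds:
compound 1 `O=c1[nH]cc(S(=O)(=O)Nc2ccccc2-c2cn(-c3cccc(Cl)c3)nn2)c(=O)[nH]1` gives 2180 nM
compound 2 `O=c1[nH]cc(S(=O)(=O)Nc2ccccc2-c2cn(-c3ccc(Cl)cc3)nn2)c(=O)[nH]1` gives 1750 nM
compound 3 `O=c1[nH]cc(S(=O)(=O)Nc2cccc(-c3cn(-c4cccc(Cl)c4)nn3)c2)c(=O)[nH]1` gives 3410 nM

All three were tested in a functional assay on OVCAR-3 cells (Homo sapiens) for antiproliferative activity, read by MTT assay, with a stated time of 24 h; on this read-out higher numbers stand for weaker inhibition and lower numbers for stronger inhibition. Compound 1 and compound 2 differ by 4-chlorophenyl in place of 3-chlorophenyl on an aromatic nitrogen and this change gave a 1.2-fold lower number from compound 1 to compound 2 (0.10 log units; within the scatter). Compound 3 has a different core from compound 1; the difference between the two cores is not broken down here, and the two values lie within the scatter of each other.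

Compound 4 `O=c1[nH]cc(S(=O)(=O)Nc2cccc(-c3cn(-c4ccc(Cl)cc4)nn3)c2)c(=O)[nH]1` is not yet measured. It differs from compound 3 by 4-chlorophenyl in place of 3-chlorophenyl on an aromatic nitrogen, the same change seen between compound 1 and compound 2. For compound 4 a step of a 1.2-fold lower number from compound 3 to compound 4 (0.07 log units; within the scatter) is expected, resting on the step of a 1.2-fold lower number from compound 1 to compound 2 (0.10 log units; within the scatter). Compound 4 is estimated at 2900 nM, between 1400 nM and 6000 nM.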

Compound 4, half-maximal inhibitory concentration: 2040 nM
The estimate for compound 4 lay 1.4-fold (0.15 log units) above the measured number; the range from low to high includes it.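

Putting 4-chlorophenyl in place of 3-chlorophenyl on the core of compound 3 gave a 1.7-fold lower number from compound 3 to compound 4 (0.22 log units; within the scatter) in this assay. Set beside the earlier step, the change reads alike on both cores: the same change on two cores in this assay, a 1.2-fold lower number (0.10 log units; within the scatter) from compound 1 to compound 2 and a 1.7-fold lower number (0.22 log units; within the scatter) from compound 3 to compound 4, 1.3-fold (0.13 log units) apart, within the scatter of two such steps. Each step on its own lies within the scatter, however, so these compounds do not show that moving the chlorine matters on either core, and two cores say nothing about any other core in this series.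

The compounds shown carry only a chlorine on this phenyl ring, so it stays open how a methoxy group, an amine or a carboxylic acid there would read. Also open, from the compounds shown here alone, is how a plain phenyl without chlorine would compare.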